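This account rests on a few compounds, and the source may have more. Where it says the series, first, only, none or still open, it means among the compounds named here.

Measured in a functional assay on KB cells (Homo sapiens) for antiproliferative activity, read by MTT assay, with a stated time of 72 h; on this read-out higher numbers stand for weaker inhibition and lower numbers for stronger inhibition:
- compound 1 `CCOC(=O)c1cc(-c2cc(OC)c(OC)c(OC)c2)c(-c2ccc(OC)cc2)s1`: 13200 nM
- compound 2 `CCOC(=O)c1cc(-c2cc(OC)c(OC)c(OC)c2)c(-c2ccc3ccccc3c2)s1`: 5890 nM

Compound 1, at 13200 nM, holds the higher of the two numbers in this assay, which makes it the weaker inhibitor of the pair. The next compound to be read is compound 3 `COc1ccc(-c2sc(C(=O)O)cc2-c2cc(OC)c(OC)c(OC)c2)cc1`, which differs from compound 1 by hydrogen in place of ethyl on an oxygen next to a carbonyl group. In words, this is hydrogen in place of ethyl on an oxygen next to a carbonyl group, or ethoxycarbonyl to carboxy.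

Among the compounds with values here, only one measured step is available, a 2.2-fold lower number from compound 1 to compound 2 (0.35 log units; beyond the scatter). It is modest and concerns a different place, an aromatic carbon. Within the data shown here, no measured step touches the ethoxycarbonyl group, so the data give no direct guide and the size of the coming step is a judgement. A modest to moderate move towards a higher number in this assay is expected, with a wide margin, and a result within the scatter of compound 1 would not be surprising. For compound 3 the estimated value is 25000 nM, with an expected range of 8000 nM to 80000 nM. The estimate means an expected 1.9-fold higher number from compound 1 to compound 3 (0.28 log units; within the scatter).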

Compound 3, half-maximal inhibitory concentration: 10400 nM
Compound 3: the middle estimate sits 2.4-fold (0.38 log units) above what was measured, within the range that was stated.
By their numbers in this assay, from the lowest: compounds 2, 3 and 1 (each within the scatter of the next, the first and the last beyond it).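

The ester place now has its first reading: in this assay, hydrogen in place of ethyl on an oxygen next to a carbonyl group gives a 1.3-fold lower number from compound 1 to compound 3 (0.10 log units; within the scatter) and so ethoxycarbonyl and carboxy cannot be told apart on the core of compound 1. Within the data shown here, the loss of ethyl, 2 heavy atoms with no ring, therefore leaves no separation on this read-out, whereas the only earlier step, at an aromatic carbon, was printed as beyond the scatter. No accompanying measurement bears on this result.

From the compounds shown here alone, whether other groups at this place, such as a primary amide, a methyl ester or a longer chain on the oxygen, would separate from compound 1 in this assay remains open. Also open, going by these compounds, is whether the ethoxycarbonyl to carboxy change reads the same with naphthalen-2-yl, the group carried by compound 2, as this change is seen here only with 4-methoxyphenyl on the shared core.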